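Shifting the Fluorine on the Amide Nitrogen Aryl Group

This account rests on a few compounds, and the source may have more. Where it says the series, first, only, none or still open, it means among the compounds named here.

Of the compounds shown here, two have so far been measured in an ADME assay on S9 fraction from liver (Homo sapiens) for metabolic stability, read by LC-MS, using NADPH, with a stated time of 60 min, tested at 1 uM; on this read-out higher numbers stand for a longer-lived compound and lower numbers for a shorter-lived compound. Compound 1 `Cc1ccccc1N(C)C(=O)c1ccc(-c2ccc(OS(N)(=O)=O)cc2F)o1` gives 0.85 h, and compound 2 `Cc1ccc(F)cc1N(C)C(=O)c1ccc(-c2ccc(OS(N)(=O)=O)cc2)o1` gives 0.567 h. These two values lie within the usual scatter of each other, so the numbers do not separate compound 2 from compound 1.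

Compound 3 `Cc1c(F)cccc1N(C)C(=O)c1ccc(-c2ccc(OS(N)(=O)=O)cc2)o1` has the same atoms as compound 2, joined differently (3-fluoro-2-methylphenyl in place of 5-fluoro-2-methylphenyl on an amide-type nitrogen). It carries 3-fluoro-2-methylphenyl in place of 5-fluoro-2-methylphenyl on an amide-type nitrogen. Going by the values given here, no measured pair shows what such a change does, so no step beyond the scatter is expected in this assay, in either direction. The expectation starts from compound 2 at 0.567 h. The estimated change is small, a 1.1-fold higher number from compound 2 to compound 3 (0.02 log units; within the scatter). Compound 3 is expected at 0.6 h, with an estimated range from 0.3 h to 1.2 h.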

Compound 3, half-life: 0.35 h
Compound 3: the middle estimate sits 1.7-fold (0.23 log units) above what was measured; low and high end bracket the measured number.
By their numbers in this assay, from the lowest: compounds 3, 2 and 1 (each within the scatter of the next, the first and the last beyond it).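

In this assay, going by these compounds alone, this pair gives the first reading of what the placement of the fluorine does, as 3-fluoro-2-methylphenyl in place of 5-fluoro-2-methylphenyl on an amide-type nitrogen corresponds to a step (a 1.6-fold lower number from compound 2 to compound 3 (0.21 log units; within the scatter)) that the numbers do not separate from the usual scatter. Compound 2 and compound 3 have the same atoms, joined differently, so the comparison concerns this one change alone, and on this half-life read-out it does not distinguish the two compounds. Nothing given here bears on what lies behind this result.

The compounds shown leave open whether a chlorine atom or a methoxy group in place of the fluorine would give a step beyond the scatter. They also leave open what an ethyl group or a longer chain would do in place of the saturated chain carbon on the amide-type nitrogen.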